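The compounds below may be only part of what the source reports. "The series", "measured", "known", "first", "only" and "open" are said of these compounds alone.

Working notes on the series. In a functional assay on A549 cells (Homo sapiens) for cytotoxicity, read by MTT assay, with a stated time of 48 h (a higher number here means a weaker inhibitor, a lower number a stronger inhibitor), compound 1 `C#CC1=CC[C@]2(CC1)C(=C)CC[C@H]2C(C)C` gives 103000 nM. Within the data shown here, compound 2 `C=C1CCC[C@]2(C)CCC(c3cn(-c4ccc(C(C)=O)cc4)nn3)=CC[C@@]12C` gives 46400 nM, the lower of the two numbers so far, and its gap to compound 1 lies beyond the scatter. Compound 3 `C=C1CCC[C@]2(C)CCC(c3cn(-c4ccc(I)cc4)nn3)=CC[C@@]12C` has not yet been measured and differs from compound 2 at one place: iodo in place of acetyl on an aromatic carbon. This puts iodo in place of acetyl on an aromatic carbon, para to a large group, so 4-acetylphenyl becomes 4-iodophenyl. Among the measured compounds shown here, no measured pair shows what a change at this place does, so the closest anchor is compound 2 at 46400 nM. The expected result is a 1.2-fold lower number from compound 2 to compound 3 (0.09 log units; within the scatter), a small step that is not expected to go beyond the scatter. For compound 3 the estimated value is 38000 nM, with an expected range of 16000 nM to 90000 nM.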

Compound 3, half-maximal inhibitory concentration: 137000 nM
Beside the measured number, compound 3's estimate is 3.6-fold (0.56 log units) below it; measured number outside the range, above it.
By their numbers in this assay, from the lowest: compound 2; then compounds 1 and 3 (each within the scatter of the next).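

Among these compounds, the first readable step sits at this position: in this assay, replacing acetyl with iodo on the aromatic carbon para to a large group gives a 3.0-fold higher number from compound 2 to compound 3 (0.47 log units; beyond the scatter). The position therefore responds to the group it carries, and in this single pair the lower number belongs to 4-acetylphenyl rather than 4-iodophenyl. The change removes a carbonyl and a hydrogen-bond acceptor, but no measurement here separates those features from the other differences between the two groups, and nothing available bears on the reason for the step.

One pair gives no trend across substituents at this place. On these data alone, how an amine, a carboxylic acid or a longer chain in place of acetyl would read remains open, as does whether a hydrogen-bond acceptor other than the carbonyl of acetyl would give a similar number.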